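Methoxy for fluoro on the aryl group of compound 3

A few compounds are considered here, and "the series" means these few. Any claim that something is new, unique, unknown or untested is made for them only; others in the source may bear on it.

compound 1 `COc1ccc(-c2nn(-c3ccccc3)cc2C(Nc2nc3ccccc3s2)c2c(O)ccc3ccccc23)cc1`: 9340 nM
compound 2 `COc1ccc2nc(NC(c3cn(-c4ccccc4)nc3-c3ccc([N+](=O)[O-])cc3)c3c(O)ccc4ccccc34)sc2c1`: 5540 nM
compound 3 `COc1ccc2nc(NC(c3cn(-c4ccccc4)nc3-c3ccc(F)cc3)c3c(O)ccc4ccccc34)sc2c1`: 4630 nM

All three values come from a functional assay on HeLa cells (Homo sapiens) for antiproliferative activity, read by MTT assay, with a stated time of 48 h; a lower number here means a stronger inhibitor, a higher number a weaker inhibitor. Compound 3, at 4630 nM, lies within the scatter of both compound 2 and compound 1, so these numbers give no ranking.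

Compound 4 `COc1ccc(-c2nn(-c3ccccc3)cc2C(Nc2nc3ccc(OC)cc3s2)c2c(O)ccc3ccccc23)cc1` has methoxy in place of fluoro on an aromatic carbon, para to a large group, which reads as 4-fluorophenyl to 4-methoxyphenyl (methoxy in place of fluoro on an aromatic carbon). Among the compounds with values here, the only measured step at this carbon is a 1.2-fold lower number from compound 2 to compound 3 (0.08 log units; within the scatter), with fluoro in place of nitro, and it stays within the scatter. Compound 1, at 9340 nM, already carries the 4-methoxyphenyl group but lacks the second methoxy of compound 4, so it bears on the change only indirectly. Within the data shown here, no measured pair isolates this exact swap.

The step expected in this assay is a 1.2-fold higher number from compound 3 to compound 4 (0.07 log units; within the scatter), with no expected change beyond the scatter. The estimated value for compound 4 is 5500 nM, with an expected range of 2800 nM to 10500 nM.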

Compound 4, half-maximal inhibitory concentration: 9240 nM
Estimate against measurement, compound 4: 1.7-fold (0.23 log units) below, and the stated range covers the measured number.
By their numbers in this assay, from the lowest: compounds 3, 2, 4 and 1 (each within the scatter of the next).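

In this assay the 4-fluorophenyl to 4-methoxyphenyl change gives a 2.0-fold higher number from compound 3 to compound 4 (0.30 log units; within the scatter) and methoxy in place of nitro on the same carbon gives a 1.7-fold higher number from compound 2 to compound 4 (0.22 log units; within the scatter) so fluoro, nitro and methoxy at this carbon now stand within the scatter of one another across compounds 2, 3 and 4. The other methoxy, in place of hydrogen on an aromatic carbon, gives a 1.0-fold lower number from compound 1 to compound 4 (0.00 log units; within the scatter) and this first step at that second place also stays within the scatter. So neither place has yet produced a step beyond the scatter in this series. No measurement at hand offers an explanation for these steps.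

Within the data shown here, whether any group at the first carbon moves the number beyond the scatter remains open, and an amine, a carboxylic acid or a longer alkoxy chain there would test this. The second place is also open, with only hydrogen and methoxy shown.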